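The compounds below may be only part of what the source reports. "The series", "measured", "known", "first", "only" and "open" are said of these compounds alone.

Compound 3, with the structure `Cn1ncc(Cl)c1-c1cc(C(=O)N[C@@H]2CN[C@H](CC(N)=O)C[C@H]2c2ccc(Cl)c(Cl)c2)oc1Cl`, is one of three compounds whose numbers are known in an assay for inhibition of RAC-alpha serine/threonine-protein kinase (Homo sapiens), read by HTRF, with a stated time of 1 h (a lower number here means a stronger inhibitor, a higher number a weaker inhibitor), where compound 3 gives 3.24 nM. Compound 1, `Cn1ncc(Cl)c1-c1cc(C(=O)N[C@@H]2CN[C@H](CC(O)CO)C[C@H]2c2ccc(Cl)c(Cl)c2)oc1Cl`, gives 3.79 nM in this assay, and compound 2, `Cn1ncc(Cl)c1-c1cc(C(=O)N[C@@H]2CN[C@H](CCO)C[C@H]2c2ccc(F)c(F)c2)oc1Cl`, gives 0.98 nM. On these numbers compound 3 sits second highest of the three: its nearest neighbour is compound 1, and its furthest is compound 2, which lies beyond the scatter from it. Going by the values given here, the one measured step that changes the same place, a 1.2-fold lower number from compound 1 to compound 3 (0.07 log units; within the scatter), is within the scatter, so swapping one polar group for another on that chain carbon did nothing that the assay could see.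

The step to compound 4, `CCC[C@@H]1C[C@@H](c2ccc(Cl)c(Cl)c2)[C@H](NC(=O)c2cc(-c3c(Cl)cnn3C)c(Cl)o2)CN1`, is ethyl in place of carbamoyl on a saturated chain carbon bound to a saturated ring carbon. Among the compounds with values here, no measured step removes a hydrogen-bond donor and acceptor from this position outright, so the only guide is that the chain at this place tolerated the exchange just described without a shift. On that basis compound 4 is expected to show a step of a 1.4-fold higher number from compound 3 to compound 4 (0.14 log units; within the scatter) from compound 3, not beyond the scatter. The estimate for compound 4 in this assay is therefore 4.5 nM, with a range from 1.5 nM to 14 nM.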

Compound 4, half-maximal inhibitory concentration: 10.4 nM
For compound 4 the middle estimate is 2.3-fold (0.36 log units) below the measured one; the measured number falls inside the stated range.
By their numbers in this assay, from the lowest: compound 2; then compounds 3 and 1 (each within the scatter of the next); then compound 4.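

The earlier compounds shown here showed only that carbamoyl and 1,2-dihydroxyethyl on this saturated chain carbon could be exchanged without a change that could be read in this assay. Ethyl at the same place is the first change there to go beyond the scatter, with a 3.2-fold higher number from compound 3 to compound 4 (0.51 log units; beyond the scatter) and, measured against the other side chain, a 2.7-fold higher number from compound 1 to compound 4 (0.44 log units; beyond the scatter), so this position is not indifferent to what it carries: both steps point the same way and are modest in size, and the group entering has 0 hydrogen-bond donors and 0 hydrogen-bond acceptors where the carbamoyl it replaces has one of each. No measurement at hand accounts for this shift, so the link between those counts and the higher number remains only a coincidence of two listed facts.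

With a single compound carrying a plain carbon chain here, the shown series cannot separate the loss of the carbamoyl atoms from the arrival of the ethyl itself. Going by these compounds, how an amine, a carboxylic acid or a longer carbon chain on this chain carbon would read in this assay stays open, as does the effect of the hydroxyl-bearing chain of compound 2 on the dichlorophenyl core.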